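A few compounds are considered here, and "the series" means these few. Any claim that something is new, unique, unknown or untested is made for them only; others in the source may bear on it.

Three compounds of the series have so far been run in a functional assay on TK-10 cells (Homo sapiens) for cytotoxicity, read by sulforhodamine B assay, with a stated time of 48 h, tested at 0.001 uM; on this read-out higher numbers stand for a weaker effect at the one concentration tested and lower numbers for a stronger effect. Compound 1 `COc1cc(C)cc(-c2c(-c3ccnc(-c4ccc(C(C)=O)cc4)c3)cnn2CC#N)c1` gives 103% in this assay, compound 2 `COc1cc(C)cc(-c2nn(CC#N)cc2-c2ccc(-c3cccc(C(C)=O)c3)nc2)c1` gives 99%, and compound 3 `Cc1cc(O)cc(-c2nn(CC#N)cc2-c2ccnc(-c3ccc(Oc4ccccc4)cc3)c2)c1` gives 91%. Compound 3 thus holds the lowest of the three numbers; its gap to compound 2 lies within the scatter, its gap to compound 1 beyond it. Compound 4 `Cc1cc(O)cc(-c2nn(CC#N)cc2-c2ccnc(-c3ccc(N(C)C)cc3)c2)c1` differs from compound 3 in one place: dimethylamino in place of phenoxy on an aromatic carbon. Going by the values given here, no pair of measured compounds differing in a single place is available for this assay, and all three numbers sit close together near the top of the scale, so no step beyond the scatter is expected; the estimated step is a number 4 percentage points higher from compound 3 to compound 4 (within the scatter). Compound 4 is estimated at 95%, in the range 82% to 108%.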

Compound 4, a percentage reported as activity, at one concentration (the size of the read-out at that concentration, not a potency): 105%
Compound 4: middle estimate off by 10 percentage points, on the low side, within the range that was stated.
By their numbers in this assay, from the lowest: compounds 3, 2, 1 and 4 (each within the scatter of the next, the first and the last beyond it).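

Going by these compounds alone, the first single-place step in this assay is modest: a number 14 percentage points higher from compound 3 to compound 4 (beyond the scatter), with dimethylamino in place of phenoxy on an aromatic carbon, para to a large group. This position therefore does not leave the read-out unchanged, and in this one pair the phenoxy compound lies on the side of the stronger effect. Nothing at hand bears on the reason for this step. As far as these compounds go, whether methoxy or a primary amine on the same carbon would read like compound 3 or compound 4 stays open. From the compounds shown here alone, whether this step holds on other cores of the series also stays open.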